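Trifluoromethoxy for Fluoro in a Series at the Limit

The source may report more compounds than this note shows. Statements on the series, on what has been measured and on what is new or still open speak of the compounds shown alone.

Compound 1 `COc1cc(-n2ncnc2-c2ccc(F)cc2)cc(OC)c1OC` was tested in a functional assay on Jurkat cells (Homo sapiens) for antiproliferative activity, read by MTT assay, with a stated time of 72 h; a higher number here means a weaker inhibitor, a lower number a stronger inhibitor. In this assay compound 1 gives > 10000 nM, which is a limit of the assay rather than a number. Compound 2 `COc1cc(-c2ncnn2-c2ccc(F)cc2)cc(OC)c1OC` gives > 10000 nM, likewise a limit. Compound 3 `COc1cc(-n2ncnc2-c2cccc(Cl)c2)cc(OC)c1OC` gives > 10000 nM, also a limit. Among the compounds with values here, the only single change among the measured compounds, a step that the two limits leave unreadable from compound 1 to compound 3, cannot be read in size because of the limit of > 10000 nM in this assay, at which 3 of the 3 values shown sit. Compound 4 `COc1cc(-n2ncnc2-c2ccc(OC(F)(F)F)cc2)cc(OC)c1OC` differs from compound 1 by trifluoromethoxy in place of fluoro on an aromatic carbon. Within the data shown here, no measured step shows what this change does, so any expectation rests only on where compound 1 stands. Compound 4 is therefore expected at 15000 nM, within 4000 nM to 60000 nM, most likely reported again as a limit. The expected step that the limit leaves unreadable from compound 1 to compound 4 is accordingly about none.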

Compound 4, half-maximal inhibitory concentration: > 10000 nM
Compound 4: only a limit was reported (the forecaster's own chance of this, stated with the estimate: 80%); the middle value lies beyond the limit too.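

No size can be given for the change from compound 1 to compound 4, because both results are limits, not numbers: the limit of > 10000 nM in this assay, at which 4 of the 4 values shown sit. The compounds shown leave open how fluoro and trifluoromethoxy compare, and which change to the shared core, if any, would give a readable number.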